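Swapping the hydroxyphenyl end of a shared core

The compounds below may be only part of what the source reports. "The series", "measured", "known", "first", "only" and "open" are said of these compounds alone.

Compound 1 `COc1cc(NC(C)CCCNC(=O)NNC(=O)Nc2ccc(C(F)(F)F)cc2)c2ncccc2c1` gives 18000 nM
Compound 2 `COc1cc(NC(C)CCCNC(=O)Nc2cccc(O)c2)c2ncccc2c1` gives 32000 nM
Compound 3 `COc1cc(NC(C)CCCNC(=O)NNC(=O)Nc2cc(C(F)(F)F)cc(C(F)(F)F)c2)c2ncccc2c1` gives 13000 nM

All three numbers come from a functional assay on CCRF-CEM cells (Homo sapiens) for inhibition, read by MTT assay, with a stated time of 72 h (a higher number here means a weaker inhibitor, a lower number a stronger inhibitor), and can be compared directly. Compound 2 stands level with compound 1 within the usual scatter of such measurements, while its number lies above that of compound 3 by a gap beyond that scatter.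

The next compound to be tested is compound 4 `COc1cc(NC(C)CCCNC(=O)NNC(=O)Nc2ccc(O)cc2)c2ncccc2c1` and it keeps the shared core of compound 2. The change puts ((4-hydroxyphenyl)carbamoyl)amino in place of 3-hydroxyphenyl on an amide-type nitrogen.

Among the compounds with values here, no measured pair shows this swap on its own, so any forecast is rough. The closest guides are compound 1 at 18000 nM and compound 3 at 13000 nM. Both already carry a carbamoylamino unit on that nitrogen, though with trifluoromethyl groups on the ring where compound 4 has a hydroxy group. Their numbers do not lie far from that of compound 2, so no large change is expected in this assay and any shift should lean slightly towards a lower number. The step of a 1.3-fold lower number from compound 2 to compound 4 (0.12 log units; within the scatter) is expected to stay within the scatter. Compound 4 is estimated at 24000 nM (expected range 10000 nM to 60000 nM).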

Compound 4, half-maximal inhibitory concentration: 111000 nM
Beside the measured number, compound 4's estimate is 4.6-fold (0.67 log units) below it; the measured number lies above the stated range.
By their numbers in this assay, from the lowest: compounds 3, 1 and 2 (each within the scatter of the next, the first and the last beyond it); then compound 4.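

In this assay, within the data shown here, putting ((4-hydroxyphenyl)carbamoyl)amino in place of 3-hydroxyphenyl on the amide-type nitrogen gives a 3.5-fold higher number from compound 2 to compound 4 (0.54 log units; beyond the scatter), so this end of the molecule can weaken inhibition by more than the usual scatter, which the first three compounds, with no step between them, could not show. The second step isolates the ring substituent on the longer end: hydroxy in place of trifluoromethyl on an aromatic carbon gives a 6.2-fold higher number from compound 1 to compound 4 (0.79 log units; beyond the scatter), so carrying the carbamoylamino unit does not by itself settle the number, and what sits on the ring matters as well. No measurement shown here accounts for either step.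

The first step changes both the length of the end group and the place of the hydroxy group, so the compounds shown leave open how much of it belongs to each, and a ((3-hydroxyphenyl)carbamoyl)amino end would separate the two. Also open, from the compounds shown here alone, is where a methoxy group, an amine or a carboxylic acid on that ring would fall relative to hydroxy and trifluoromethyl.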